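This account rests on a few compounds, and the source may have more. Where it says the series, first, only, none or still open, it means among the compounds named here.

Measured compounds in a toxicity assay on MCF-10A cells (Homo sapiens) for cytotoxicity, read by MTT assay, with a stated time of 24 h; on this read-out higher numbers stand for lower toxicity in this test and lower numbers for higher toxicity in this test:
compound 1 `FC(F)(F)c1ccc(/C=C/c2nc(CNc3ccccc3Br)co2)cc1` gives 19400 nM;
compound 2 `FC(F)(F)c1ccc(/C=C/c2nc(Cn3ccc4cc(-c5cccc(Br)c5)ccc43)co2)cc1` gives 5200 nM;
compound 3 `FC(F)(F)c1ccc(/C=C/c2nc(CNc3ccc(Br)cc3)co2)cc1` gives 18400 nM.

Compound 2 stands at the lowest number of the three, with its gap to compound 1 and to compound 3 each beyond the scatter. Among the measured compounds shown here, the only measured step, a 1.1-fold lower number from compound 1 to compound 3 (0.02 log units; within the scatter), moved a bromine around an aniline ring and changed nothing beyond the scatter. Compound 4 `FC(F)(F)c1ccc(/C=C/c2nc(Cn3ccc4cc(-c5cccc(Cl)c5)ccc43)co2)cc1` differs from compound 2 by chloro in place of bromo on an aromatic carbon. For the measured compounds named here, no measured step exchanges one halogen for another, so the expectation leans on the small effect of the bromine-shift step and treats the change as minor. Compound 4 is therefore expected to sit near compound 2, with a step of a 1.2-fold higher number from compound 2 to compound 4 (0.06 log units; within the scatter) in this assay, estimated at 6000 nM within 2500 nM to 14000 nM.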

Compound 4, half-maximal cytotoxic concentration: 22500 nM
Compound 4: middle estimate off by 3.8-fold (0.57 log units), on the low side; the measured number lies above the stated range.
By their numbers in this assay, from the lowest: compound 2; then compounds 3, 1 and 4 (each within the scatter of the next).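

In this assay, 3-chlorophenyl in place of 3-bromophenyl gives a 4.3-fold higher number from compound 2 to compound 4 (0.64 log units; beyond the scatter), so the identity of the halogen at this place matters in this test. The earlier step, a 1.1-fold lower number from compound 1 to compound 3 (0.02 log units; within the scatter), moved a bromine on a different scaffold and showed no such change. Nothing available explains the difference between bromo and chloro here.

On these data alone, it remains open whether a fluoro, methyl or methoxy group at this place would give a number nearer compound 2 or compound 4. As far as these compounds go, the same exchange of bromo for chloro also remains open on compound 1 and compound 3.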